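This account rests on a few compounds, and the source may have more. Where it says the series, first, only, none or still open, it means among the compounds named here.

The measured compounds:

compound 1, `Cc1cc(Nc2cc(-c3ccccc3)[nH]n2)n2nc(SCc3c(Cl)cccc3Cl)nc2n1`: 5280 nM
compound 2, `Cc1cc(Nc2cc(-c3ccccc3)[nH]n2)n2nc(SCc3ccc(Br)cc3)nc2n1`: 1110 nM
compound 3, `Cc1cc(Nc2cc(-c3ccccc3)[nH]n2)n2nc(SCc3ccccc3Br)nc2n1`: 3650 nM

All three share one core and differ only in the aryl group sitting on a saturated chain carbon bound to a sulfur. In a functional assay on MGC-803 cells (Homo sapiens) for inhibition, read by MTT assay, with a stated time of 72 h (on this read-out higher numbers stand for weaker inhibition and lower numbers for stronger inhibition), compound 1 gives the highest of the three numbers. Compound 3 lies nearest to it: a 1.4-fold lower number from compound 1 to compound 3 (0.16 log units; within the scatter). Compound 2 lies furthest away: a 4.8-fold lower number from compound 1 to compound 2 (0.68 log units; beyond the scatter). Between the two bromo compounds, a 3.3-fold higher number from compound 2 to compound 3 (0.52 log units; beyond the scatter).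

Compound 4, `Cc1cc(Nc2cc(-c3ccccc3)[nH]n2)n2nc(SCc3nc4ccccc4[nH]3)nc2n1`, has not yet been measured in this assay. It differs from compound 1 in one place: 1H-benzimidazol-2-yl in place of 2,6-dichlorophenyl on a saturated chain carbon bound to a sulfur. For the measured compounds named here, none of the measured steps swaps in a group of this kind, so no step bears directly on the change. Going by the values given here, the measured steps show only that swapping the aryl group at that carbon moved the number by modest amounts, and in both measured cases downward from compound 1. On that basis a modest lowering from compound 1 is expected for compound 4, with wide uncertainty: a 1.8-fold lower number from compound 1 to compound 4 (0.25 log units; within the scatter). Compound 4 is therefore estimated at 3000 nM in this assay, within a range from 800 nM to 12000 nM.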

Compound 4, half-maximal inhibitory concentration: 1790 nM
The estimate for compound 4 lay 1.7-fold (0.22 log units) above the measured number; low and high end bracket the measured number.
By their numbers in this assay, from the lowest: compounds 2 and 4 (each within the scatter of the next); then compounds 3 and 1 (each within the scatter of the next).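

In this assay, compound 4 shows that the aryl group on a saturated chain carbon bound to a sulfur need not be a halogen-bearing phenyl: 1H-benzimidazol-2-yl, with its five-membered aromatic ring with 2 hetero atoms, its hydrogen-bond donor and its hydrogen-bond acceptor, gives a 2.9-fold lower number from compound 1 to compound 4 (0.47 log units; beyond the scatter) and a 2.0-fold lower number from compound 3 to compound 4 (0.31 log units; beyond the scatter). Against the 4-bromophenyl group, the same swap gives a 1.6-fold higher number from compound 2 to compound 4 (0.21 log units; within the scatter), so compound 4 and compound 2 cannot be told apart here, and the two very different groups both stand clear of the 2,6-dichlorophenyl and 2-bromophenyl groups. Nothing available explains why the number shifts with this change.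

The compounds shown leave open whether the hydrogen-bond donor of the 1H-benzimidazol-2-yl group matters, a question that a methyl group on its ring nitrogen would address, and whether the fused ring matters at all. On these data alone, how an unsubstituted phenyl, a carboxylic acid or an amine on the phenyl, or a longer chain in place of the single saturated carbon would read in this assay also remains open.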